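The source may hold more compounds than are shown below. What is called first, only, known or untested is meant among the compounds shown, and "the series" means these compounds.

Measured in a functional assay on A549 cells (Homo sapiens) for antiproliferative activity, read by WST assay, with a stated time of 120 h; a lower number here means a stronger inhibitor, a higher number a weaker inhibitor:
Compound 1 `CCC[C@H]1C[C@@H](OC)C/C(C)=C\[C@@H]2C[C@@H](OC(=O)c3ccccc3CCc3coc(/C=C\CNC(=O)OC)n3)C[C@H](CC(=O)O1)O2` gives 500 nM
Compound 2 `CCC[C@H]1C[C@@H](OC)C/C(C)=C\[C@@H]2C[C@@H](OC(=O)/C(C)=C\CCc3coc(/C=C\CNC(=O)OC)n3)C[C@H](CC(=O)O1)O2` gives 2.5 nM
Compound 3 `C/C=C\c1nc(CC/C=C\C(=O)O[C@H]2C[C@@H]3CC(=O)O[C@@H](CCC)C[C@@H](OC)C/C(C)=C\[C@H](C2)O3)co1` gives 740 nM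

Compound 3, at 740 nM, stands within the scatter of compound 1, while compound 2, at 2.5 nM, lies far beyond the scatter from it.

Compound 4 `CCC[C@H]1C[C@@H](OC)C/C(C)=C\[C@@H]2C[C@@H](OC(=O)/C=C\CCc3coc(CCCNC(=O)OC)n3)C[C@H](CC(=O)O1)O2` has not yet been measured. It departs from compound 3 at one place, on an aromatic carbon of a five-membered aromatic ring with 1 nitrogen and 1 oxygen: 3-((methoxycarbonyl)amino)propyl in place of prop-1-en-1-yl (3-((methoxycarbonyl)amino)propyl in place of prop-1-en-1-yl on an aromatic carbon).

For the measured compounds named here, no measured pair isolates this change, so the three values offer only indirect guidance. Compound 2, at 2.5 nM, carries a chain with the same methoxycarbonyl amino ending at this place, but it also differs from compound 3 elsewhere. Compound 1 goes against any simple reading: it has that ending too, yet gives 500 nM.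

In this assay, a step towards a lower number is therefore expected, sizeable but short of the whole gap to compound 2. The estimated step is a 25-fold lower number from compound 3 to compound 4 (1.39 log units; beyond the scatter). For compound 4 the estimated value is 30 nM, with an expected range of 5 nM to 200 nM.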

Compound 4, half-maximal inhibitory concentration: 400 nM
For compound 4 the middle estimate is 13-fold (1.12 log units) below the measured one; the measured number lies above the stated range.
By their numbers in this assay, from the lowest: compound 2; then compounds 4, 1 and 3 (each within the scatter of the next).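

In this assay, putting 3-((methoxycarbonyl)amino)propyl in place of prop-1-en-1-yl on an aromatic carbon of the five-membered aromatic ring gives a 1.9-fold lower number from compound 3 to compound 4 (0.27 log units; within the scatter). This position therefore accepts a chain of 8 heavy atoms, bearing a hydrogen-bond donor and hydrogen-bond acceptors, in place of one of 3 heavy atoms, without a step beyond the scatter, so the methoxycarbonyl amino ending on a saturated propyl chain does not alone set a compound apart from compound 3. No measurement available here accounts for this result.

From the compounds shown here alone, whether a primary amine or a carboxylic acid at the end of the propyl chain, or a longer chain carrying the same carbamate ending, would also stay within the scatter of compound 3 remains open. Compound 2 differs from compound 4 in more than one place, as do the other remaining pairs among these compounds, so those steps cannot be read and the origin of the value of compound 2 stays unresolved.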